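The compounds below may be only part of what the source reports. "The series", "measured", "known", "first", "only" and "open" are said of these compounds alone.

Working notes on the series. Compound 1 `CN(C)CCn1cnnc1-c1cc(Oc2ccc(NC(=O)N/N=C/c3ccc(F)cc3Cl)cc2F)ccn1` gives 510 nM in a functional assay on HT-29 cells (Homo sapiens) for cytotoxicity, read by MTT assay, with a stated time of 72 h; a higher number here means a weaker inhibitor, a lower number a stronger inhibitor. Compound 2 `CN(C)CCn1cnnc1-c1cc(Oc2ccc(NC(=O)N/N=C/c3ccc(O)c(F)c3)cc2F)ccn1` gives 3310 nM, and compound 3 `CN(C)CCn1cnnc1-c1cc(Oc2ccc(NC(=O)N/N=C/c3c[nH]c4ccccc34)cc2F)ccn1` gives 1300 nM, which places compound 3 second highest of the three numbers, with a 2.5-fold higher number from compound 1 to compound 3 (0.41 log units; beyond the scatter) and a 2.5-fold lower number from compound 2 to compound 3 (0.41 log units; beyond the scatter). Compound 4 `Cc1cc(/C=N/NC(=O)Nc2ccc(Oc3ccnc(-c4nncn4CCN(C)C)c3)c(F)c2)cc(C)c1O` differs from compound 3 in one place: 4-hydroxy-3,5-dimethylphenyl in place of 1H-indol-3-yl on a carbon with a double bond to nitrogen. The step that bears on this is a 2.5-fold lower number from compound 2 to compound 3 (0.41 log units; beyond the scatter), in which a 3-fluoro-4-hydroxyphenyl was exchanged for the 1H-indol-3-yl; the 4-hydroxy-3,5-dimethylphenyl of compound 4 resembles the group of compound 2, so a return toward the higher number is expected, of roughly a 2.0-fold higher number from compound 3 to compound 4 (0.30 log units; within the scatter) in this assay. Compound 4 is therefore estimated at 2600 nM, expected within 1200 nM to 5600 nM.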

Compound 4, half-maximal inhibitory concentration: 1220 nM
For compound 4 the middle estimate is 2.1-fold (0.33 log units) above the measured one; the measured number falls inside the stated range.
By their numbers in this assay, from the lowest: compound 1; then compounds 4 and 3 (each within the scatter of the next); then compound 2.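

At this position, on a carbon with a double bond to nitrogen, a single six-membered aromatic ring with 4-hydroxy-3,5-dimethylphenyl can stand in for 1H-indol-3-yl in this assay, with a 1.1-fold lower number from compound 3 to compound 4 (0.03 log units; within the scatter). Two hydroxy-bearing phenyl groups do not read alike, with a 2.7-fold lower number from compound 2 to compound 4 (0.43 log units; beyond the scatter), yet neither reaches the 2-chloro-4-fluorophenyl of compound 1, with a 2.4-fold higher number from compound 1 to compound 4 (0.38 log units; beyond the scatter). No measurement here explains these differences. Still open, on these data alone, is whether a phenyl carrying an amine or a carboxylic acid in place of the hydroxy group would hold the number of compound 4.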